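A few compounds are considered here, and "the series" means these few. Any claim that something is new, unique, unknown or untested is made for them only; others in the source may bear on it.

Notes on the series built on the shared core of compound 1 `CCn1ccc2cc(NC(=O)CN(c3cc(Cl)ccc3OC)S(=O)(=O)c3ccccc3)ccc21`. In a functional assay on SH-SY5Y cells (Homo sapiens), read by MTT assay, with a stated time of 24 h (on this read-out higher numbers stand for an effect only at larger amounts of compound and lower numbers for an effect already at smaller amounts), compound 1 gives 2220 nM. Compound 2 `COc1ccc(Cl)cc1N(CC(=O)Nc1ccccc1)S(=O)(=O)c1ccccc1` stands at the assay limit: in this assay compound 2 gives > 20000 nM. Within the data shown here, the one measured step, an at least 9.0-fold higher number from compound 1 to compound 2 (0.95 log units; beyond the scatter), rests on (the limit of > 20000 nM in this assay, at which 1 of the 2 values shown sits), so its true size is open. Compound 3 `COc1ccc(Cl)cc1NC(=O)CN(c1cc(Cl)ccc1OC)S(=O)(=O)c1ccccc1` carries 5-chloro-2-methoxyphenyl in place of phenyl on an amide-type nitrogen. No measured step covers this change, and the one shown step concerns a different ring, so direction is uncertain. Compound 3 is expected near the limit, at 15000 nM, ranging from 4000 nM to 40000 nM. The expected step is an at least 1.3-fold lower number from compound 2 to compound 3 (0.12 log units; that floor lies within the scatter).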

Compound 3, half-maximal effective concentration: > 20000 nM
Compound 3 ended at the assay's limit; the forecaster's own chance of this, stated with the estimate: 50%; at least 1.3-fold (0.12 log units) between middle value and limit.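

In this assay, a second replacement of 1-ethyl-1H-indol-5-yl on the amide-type nitrogen, this time by 5-chloro-2-methoxyphenyl, gives an at least 9.0-fold higher number from compound 1 to compound 3 (0.95 log units; beyond the scatter), so the loss seen with phenyl is not confined to that one group. Compound 3 also sits at a limit of the assay, not at a number, so adding the chloro and methoxy groups to the phenyl yields no readable value. The step from compound 2 to compound 3 cannot be read: the limit of > 20000 nM in this assay, at which 2 of the 3 values shown sit.

Going by these compounds, the true values of compound 2 and compound 3 stay open. On these data alone, it is also open whether the ethyl group of compound 1 matters, as a methyl or propyl chain on the 1H-indol-5-yl group, or a bare 1H-indol-5-yl, could show.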